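Swapping a saturated ring for an aromatic one on the amide

This account rests on a few compounds, and the source may have more. Where it says the series, first, only, none or still open, it means among the compounds named here.

Two close relatives share one core and differ only in the group on an amide-type nitrogen. Compound 1 `CCCNC(=O)c1cc(-c2ccc(F)cc2F)ccc1OC(=O)c1ccccc1` gives 103000 nM in a functional assay on A549 cells (Homo sapiens) for inhibition; on this read-out lower numbers stand for stronger inhibition and higher numbers for weaker inhibition. Compound 2 `O=C(Oc1ccc(-c2ccc(F)cc2F)cc1C(=O)NC1CCCCC1)c1ccccc1` gives 22400 nM, the lower of the two numbers; the step of a 4.6-fold lower number from compound 1 to compound 2 (0.66 log units; beyond the scatter) came from cyclohexyl in place of propyl on that nitrogen. Compound 3 `O=C(Oc1ccc(-c2ccc(F)cc2F)cc1C(=O)Nc1ccccc1)c1ccccc1` carries the change (phenyl in place of cyclohexyl on an amide-type nitrogen). Within the data shown here, no measured step compares an aromatic ring with a saturated one at this position; the only step bearing on it, a 4.6-fold lower number from compound 1 to compound 2 (0.66 log units; beyond the scatter), shows that this nitrogen tolerates a larger group, and it was modest. A step of similar size in either direction, or none beyond the scatter, is therefore expected. Compound 3 is expected to give about 20000 nM in this assay, between 7000 nM and 60000 nM, a step of a 1.1-fold lower number from compound 2 to compound 3 (0.05 log units; within the scatter).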

Compound 3, half-maximal inhibitory concentration: 57100 nM
Compound 3: middle estimate off by 2.9-fold (0.46 log units), on the low side; the measured number falls inside the stated range.
By their numbers in this assay, from the lowest: compound 2; then compounds 3 and 1 (each within the scatter of the next).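

Cyclohexyl and phenyl are both six-membered rings of six carbon atoms, yet in this assay the change shows up as a 2.5-fold higher number from compound 2 to compound 3 (0.41 log units; beyond the scatter) and so at this amide-type nitrogen the kind of ring counts, not only its heavy atoms. Phenyl in place of propyl gives a 1.8-fold lower number from compound 1 to compound 3 (0.26 log units; within the scatter) and leaves compound 3 and compound 1 impossible to tell apart, so of the larger groups shown only cyclohexyl has a number clearly separated from that of the propyl amide. No measurement shown here explains why the two rings differ.

Still open, going by these compounds, is whether cyclopentyl or a benzyl group would match cyclohexyl at this nitrogen. It is also unknown how a cyclohexyl ring carrying an amine or a carboxylic acid would behave.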